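Chloro in place of methyl: from compound 2 to compound 3

A few compounds are considered here, and "the series" means these few. Any claim that something is new, unique, unknown or untested is made for them only; others in the source may bear on it.

Compound 1 `COc1ccccc1C(=O)Nc1nnc(SCC(=O)Nc2ccc(Br)cn2)s1` gives > 80000 nM in a functional assay on NCI-H460 cells (Homo sapiens) for antiproliferative activity, read by MTT assay, with a stated time of 48 h; a higher number here means a weaker inhibitor, a lower number a stronger inhibitor; this is a limit of the assay and not a number.
Compound 2 `COc1ccccc1C(=O)Nc1nnc(SCC(=O)Nc2ccc(C)cn2)s1` gives > 80000 nM in this assay; this too is a limit of the assay.

Compound 2 therefore stands at the ceiling of what this assay reports, with no number of its own, and the same holds for (the limit of > 80000 nM in this assay, at which 2 of the 2 values shown sit). Going by the values given here, the single measured step, a step that the two limits leave unreadable from compound 1 to compound 2, runs between two such limits and so cannot be read for size or direction.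

Compound 3 `COc1ccccc1C(=O)Nc1nnc(SCC(=O)Nc2ccc(Cl)cn2)s1` arises from compound 2 by the change (chloro in place of methyl on an aromatic carbon). Among the compounds with values here, the only measured step that bears on it is a step that the two limits leave unreadable from compound 1 to compound 2, which exchanges one small substituent for another at the same place and gave nothing readable. Within the data shown here, no step on record shows that a change at this place moves the value off the limit, so no step beyond the scatter is expected in this assay in either direction.

Compound 3 is therefore estimated to sit at the limit as well, with an expected value of 100000 nM, from 40000 nM to 250000 nM, an expected step that the limit leaves unreadable from compound 2 to compound 3.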

Compound 3, half-maximal inhibitory concentration: > 80000 nM
Compound 3: no number, only a limit; the forecaster's own chance of this, stated with the estimate: 85%; the middle value does not contradict the limit.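

In this assay compound 3 gives > 80000 nM, a limit and not a number. The steps linking compound 1, compound 2 and compound 3 therefore cannot be read, and all three compounds share one limit: the limit of > 80000 nM in this assay, at which 3 of the 3 values shown sit.

The compounds shown leave open whether any other group at this place, or any change elsewhere on the shared core, would give a measurable value.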